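Compound 1 trades its ring group for carbamoylmethyl

The source may report more compounds than this note shows. Statements on the series, on what has been measured and on what is new or still open speak of the compounds shown alone.

In a physicochemical assay for solubility, in phosphate buffer, measured as kinetic solubility (a higher number here means a more soluble compound, a lower number a less soluble compound), compound 1 `CC(C)C(c1ccc(-c2ccc3cccc(F)c3c2)[nH]c1=O)N1CCN/C1=N\C#N` gives 25200 nM and compound 2 `CC(C)[C@@H](C[C@H]1CCNC1=O)c1ccc(-c2ccc3cccc(F)c3c2)[nH]c1=O` gives 32000 nM. Within the data shown here, these two values lie within the scatter of each other, so compound 1 stands level with the only other compound measured so far. Compound 3 `CC(C)C(CC(N)=O)c1ccc(-c2ccc3cccc(F)c3c2)[nH]c1=O` has not yet been measured. It carries carbamoylmethyl in place of the ring-bearing group of compound 1, and the change reads: a group of 4 heavy atoms (2 carbon, 1 nitrogen, 1 oxygen; no ring) in place of a group of 8 heavy atoms (4 carbon, 4 nitrogen; one five-membered non-aromatic ring with 2 hetero atoms), on a saturated chain carbon bound to an aromatic carbon and a saturated chain carbon. Among the measured compounds shown here, no step between measured compounds covers this exchange, so the data give no direct guide to it. A change no larger than the scatter is expected in this assay, with no firm direction. That expectation rests only on compound 2 at 32000 nM lying within the scatter of compound 1 at 25200 nM. The estimated step is a 1.2-fold higher number from compound 1 to compound 3 (0.08 log units; within the scatter). For compound 3 the expected value is 30000 nM, with an estimated range of 12000 nM to 70000 nM.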

Compound 3, solubility: 5600 nM
Estimate against measurement, compound 3: 5.4-fold (0.73 log units) above; the whole stated range lies above it.
By their numbers in this assay, from the lowest: compound 3; then compounds 1 and 2 (each within the scatter of the next).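

In this assay, among these compounds, the exchange on this saturated chain carbon gives the first step beyond the scatter: carbamoylmethyl in place of the ring-bearing group brings a 4.5-fold lower number from compound 1 to compound 3 (0.65 log units; beyond the scatter). The position therefore matters in this assay, which could not be seen while compound 1 and compound 2, with different groups there, stood within the scatter of each other. No measurement at hand accounts for this step.

As far as these compounds go, a single step cannot separate the loss of the ring from the drop in group size, so it remains open which of the two goes with the lower number. From the compounds shown here alone, how a carboxylic acid or an amine on this carbon would stand also remains open, as does a longer chain carrying the same terminal amide.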